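A few compounds are considered here, and "the series" means these few. Any claim that something is new, unique, unknown or untested is made for them only; others in the source may bear on it.

Measured so far:
compound 1 `CN1CCN(c2nc(-c3cccc(Cl)c3)nc3c2ncn3C)CC1`: 19.2%
compound 2 `Cn1cnc2c(N3CCCCC3)nc(-c3cccc(Cl)c3)nc21`: 24.2%

In an assay on cells for displacement of a labelled ligand from adenosine receptor A2b (Homo sapiens), read by scintillation counting and radioligand binding, with a stated time of 30 min, tested at 10 uM (a lower number here means less inhibition, a higher number more inhibition at the concentration tested (going by the name of the read-out)), compound 1 gives 19.2%, the lowest of the two numbers shown; its nearest neighbour is compound 2, which gives 24.2%. Among the measured compounds shown here, the single measured step, a number 5 percentage points higher from compound 1 to compound 2 (within the scatter), lies within the scatter, so the two compounds cannot be ordered on these numbers. Compound 3 `CN1CCN(c2nc(-c3ccc(Cl)c(Cl)c3)nc3c2ncn3C)CC1` has not yet been measured. It differs from compound 1 by chloro in place of hydrogen on an aromatic carbon; cut one bond further out, the difference reads 3-chlorophenyl to 3,4-dichlorophenyl. For the measured compounds named here, no measured step bears on this ring: the only step on record concerns the amine on the core, and it stayed within the scatter. There is thus no basis for expecting a step beyond the scatter in this assay in either direction. Compound 3 is therefore expected to give 24%, with a range from 5% to 48%. The expected step is a number 4.8 percentage points higher from compound 1 to compound 3 (within the scatter).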

Compound 3, a percentage reported as inhibition, at one concentration (the size of the read-out at that concentration, not a potency): 28.3%
Compound 3: the middle estimate sits 4.3 percentage points below what was measured, and the stated range covers the measured number.
By their numbers in this assay, from the lowest: compounds 1, 2 and 3 (each within the scatter of the next).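

On the 3-chlorophenyl ring of compound 1, chloro in place of hydrogen, ortho to a chloro group and para to a large group, gives in this assay a step that reads a number 9.1 percentage points higher from compound 1 to compound 3 (within the scatter). The earlier step concerned only the amine on the core, whereas this one shows that the aromatic ring also accepts a second chloro group with no change beyond the scatter. No independent measurement bears on this result.

The compounds shown leave open whether a different group at this position, such as methoxy, a nitrile or a carboxylic acid, would give a step beyond the scatter. They also leave open whether the 3,4-dichlorophenyl ring would give a similar number with piperidin-1-yl in place of 4-methylpiperazin-1-yl on the core.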